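This account rests on a few compounds, and the source may have more. Where it says the series, first, only, none or still open, it means among the compounds named here.

In a functional assay on HepG2 cells (Homo sapiens) for inhibition, read by MTT assay, with a stated time of 72 h (a lower number here means a stronger inhibitor, a higher number a weaker inhibitor), compound 2 `O=C(OC1(C(=O)Nc2ccc([N+](=O)[O-])cc2)CCCCC1)c1ccc(Br)cc1` gives 284 nM, the higher of the two numbers measured, while compound 1 `COc1ccc(C(=O)OC2(C(=O)Nc3ccc([N+](=O)[O-])cc3)CCCCC2)cc1` gives 57.1 nM. Among the compounds with values here, the only measured step, a 5.0-fold higher number from compound 1 to compound 2 (0.70 log units; beyond the scatter), shows that a change at the aromatic substituent of the ester moves the number by a modest amount.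

Compound 3 `O=C(/C=C/c1ccccc1)OC1(C(=O)Nc2ccc([N+](=O)[O-])cc2)CCCCC1` differs from compound 2 by 2-phenylethenyl in place of 4-bromophenyl on a carbonyl carbon, so the whole 4-bromophenyl ester is exchanged for a cinnamate. Within the data shown here, the step from compound 1 to compound 2 bears on this only loosely, since it concerns a substituent on the same aryl ester rather than the replacement of that aryl by a 2-phenylethenyl group; no measured pair shows what such an exchange does. The earlier step was modest in size, and the expectation for this one is therefore a step of similar or smaller size, with its direction uncertain, though a somewhat lower number than compound 2 is thought more likely, an expected 1.9-fold lower number from compound 2 to compound 3 (0.28 log units; within the scatter). Compound 3 is accordingly estimated in this assay at 150 nM, with a range from 40 nM to 600 nM.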

Compound 3, half-maximal inhibitory concentration: 52.9 nM
Beside the measured number, compound 3's estimate is 2.8-fold (0.45 log units) above it, within the range that was stated.
By their numbers in this assay, from the lowest: compounds 3 and 1 (each within the scatter of the next); then compound 2.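

In this assay, 2-phenylethenyl in place of 4-bromophenyl on the carbonyl carbon gives a 5.4-fold lower number from compound 2 to compound 3 (0.73 log units; beyond the scatter) and so shows that this position can take a group other than a substituted phenyl and still give a low number. The same group in place of 4-methoxyphenyl gives a 1.1-fold lower number from compound 1 to compound 3 (0.03 log units; within the scatter) and so matches the lower of the two earlier numbers, which leaves compound 2 as the weakest of the three, with its steps to both others beyond the scatter. Nothing available explains either step.

The compounds shown leave open whether the double bond of the 2-phenylethenyl group counts for anything, a question that a saturated 2-phenylethyl chain would address, and whether methoxy or bromo on its ring would separate the numbers as they do on the phenyl ester. They also leave open how a simple alkyl chain, an amine or a carboxylic acid would read at this place on the carbonyl carbon.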